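The source may hold more compounds than are shown below. What is called first, only, known or untested is meant among the compounds shown, and "the series" means these compounds.

Of the compounds shown here, three built on one shared core have been tested in a functional assay on NCI-H460 cells (Homo sapiens) for cytotoxicity, read by MTT assay, with a stated time of 72 h; on this read-out lower numbers stand for stronger inhibition and higher numbers for weaker inhibition. Compound 1 `COc1cc2c(Oc3ccc(NC(=O)c4nnn(-c5ccc(F)cc5)c4C(F)(F)F)cc3F)ccnc2cc1OCCCN1CCCC1` gives 150 nM in this assay. Compound 2 `COc1cc2c(Oc3ccc(NC(=O)c4nnn(-c5ccc(C)cc5)c4C(F)(F)F)cc3F)ccnc2cc1OCCCN1CCCC1` gives 790 nM. Compound 3 `COc1cc2c(Oc3ccc(NC(=O)c4nnn(-c5ccc(F)cc5)c4C(F)(F)F)cc3F)ccnc2cc1OCCCN1CCC(C)CC1` gives 190 nM, the second highest of the three numbers, with compound 1 nearest and compound 2 furthest away. The step of a 1.3-fold higher number from compound 1 to compound 3 (0.10 log units; within the scatter) lies within the scatter, whereas the step of a 5.3-fold higher number from compound 1 to compound 2 (0.72 log units; beyond the scatter) lies beyond it.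

Compound 4 `COc1cc2c(Oc3ccc(NC(=O)c4nnn(-c5ccc(C)cc5)c4C(F)(F)F)cc3F)ccnc2cc1OCCCN1CCC(C)CC1` has not yet been measured. It differs from compound 3 by methyl in place of fluoro on an aromatic carbon. This is exactly the change that separates compound 1 from compound 2, so that step is the one that bears on the expectation; the change of the saturated ring seen between compound 1 and compound 3 does not enter here. Because the step of a 5.3-fold higher number from compound 1 to compound 2 (0.72 log units; beyond the scatter) was a modest rise, a rise of similar size is expected here: a 5.3-fold higher number from compound 3 to compound 4 (0.72 log units; beyond the scatter). Compound 4 is therefore expected to give about 1000 nM in this assay, with a likely range from 400 nM to 2500 nM.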

Compound 4, half-maximal inhibitory concentration: 1250 nM
For compound 4 the middle estimate is 1.3-fold (0.10 log units) below the measured one; the range from low to high includes it.
By their numbers in this assay, from the lowest: compounds 1 and 3 (each within the scatter of the next); then compounds 2 and 4 (each within the scatter of the next).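

The change from 4-fluorophenyl to 4-methylphenyl has now been seen with the 4-methylpiperidin-1-yl group as well as the pyrrolidin-1-yl group: in this assay it gives a 6.6-fold higher number from compound 3 to compound 4 (0.82 log units; beyond the scatter), so the rise is not confined to one saturated ring. The two rises agree within the scatter, and on these two cores the change at this place has much the same size: the same change on two cores in this assay, a 5.3-fold higher number (0.72 log units; beyond the scatter) from compound 1 to compound 2 and a 6.6-fold higher number (0.82 log units; beyond the scatter) from compound 3 to compound 4, 1.2-fold (0.10 log units) apart, within the scatter of two such steps

With methyl in place, the swap of the saturated ring gives a 1.6-fold higher number from compound 2 to compound 4 (0.20 log units; within the scatter), which, like the same swap with fluoro in place, leaves the number unchanged within the scatter: the same change on two cores in this assay, a 1.3-fold higher number (0.10 log units; within the scatter) from compound 1 to compound 3 and a 1.6-fold higher number (0.20 log units; within the scatter) from compound 2 to compound 4, 1.2-fold (0.10 log units) apart, within the scatter of two such steps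

Going by these compounds, only fluoro and methyl appear at this place, so how a chloro group, a methoxy group or a plain hydrogen there would compare stays open. The two saturated rings also leave open how a morpholine or an open-chain dimethylamine at the end of the chain would fare.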